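Swapping the Amine Arm on a Sulfonyl Group

The source may hold more compounds than are shown below. What is called first, only, known or untested is meant among the compounds shown, and "the series" means these compounds.

compound 1, `CCOC(=O)[C@@H]1CCCN(S(=O)(=O)c2ccc(S(=N)(=O)N(CC)CC)cc2)C1`, 2600 nM
compound 2, `CCOC(=O)[C@@H]1CCCN(S(=O)(=O)c2ccc(S(=O)(=O)N(C)Cc3ccccc3)cc2)C1`, > 30000 nM

Of the compounds shown here, two with a shared core have been tested in a functional assay on MIA PaCa-2 cells (Homo sapiens) for inhibition, read by MTT assay, with a stated time of 7 days; a lower number here means a stronger inhibitor, a higher number a weaker inhibitor. Compound 1 gives 2600 nM. Compound 2 reaches only > 30000 nM, which is a limit of the assay rather than a measured number; this is the limit of > 30000 nM in this assay, at which 1 of the 2 values shown sits, so compound 2 stands as the compound for which no potency could be pinned down. Among the measured compounds shown here, no step between the two can be computed, since they differ in more than one place.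

Compound 3, `CCOC(=O)[C@@H]1CCCN(S(=O)(=O)c2ccc(S(=O)(=O)N(CC)C(C)C)cc2)C1`, is not yet measured. It differs from compound 2 by ethyl(isopropyl)amino in place of benzyl(methyl)amino on a sulfonyl sulfur. Because compound 1, which also carries two small alkyl arms on its amine nitrogen, gives 2600 nM, compound 3 is expected to move back toward a measurable value, though with much uncertainty. The step from compound 2 to compound 3 is estimated as an at least 3.0-fold lower number from compound 2 to compound 3 (0.47 log units; beyond the scatter). Compound 3 is therefore expected to give about 10000 nM, within a range from 2500 nM to 30000 nM.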

Compound 3, half-maximal inhibitory concentration: 1000 nM
Beside the measured number, compound 3's estimate is 10-fold (1.00 log units) above it; measured number outside the range, below it.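

In this assay, putting ethyl(isopropyl)amino in place of benzyl(methyl)amino on a sulfonyl sulfur gives an at least 30-fold lower number from compound 2 to compound 3 (1.47 log units; beyond the scatter), which shows that the amine arm at this place can decide whether a measurable potency appears at all. Compound 2 stands at a limit of the assay rather than at a measured number, so the step can only be given as a minimum: the limit of > 30000 nM in this assay, at which 1 of the 3 values shown sits. Exchanging the whole group on the aromatic carbon, a group of 9 heavy atoms in place of a group of 8 heavy atoms, gives a more modest change, a 2.6-fold lower number from compound 1 to compound 3 (0.41 log units; beyond the scatter), so among the compounds shown, the two whose group holds no ring both reach measured values, and the one with a benzyl arm does not.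

On these data alone, what remains open is whether the difference comes from the aromatic ring of the benzyl arm or simply from the larger group as a whole. A cyclohexyl(methyl)amino group on the same sulfonyl sulfur, with a ring of carbon that is not aromatic, would help tell these two readings apart.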